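Swapping a pyrrolidine for an anilino on a sulfonamide

The compounds below may be only part of what the source reports. "The series", "measured", "known", "first", "only" and "open" are said of these compounds alone.

Of the compounds shown here, two built on the same diisopropylphenyl core have been tested in an assay on liver for inhibition of sterol O-acyltransferase 1 (Rattus norvegicus), using microsomes; a lower number here means a stronger inhibitor, a higher number a weaker inhibitor. Compound 1 `CCCCCCNS(=O)(=O)NC(=O)Nc1c(C(C)C)cccc1C(C)C` carries a hexylamino group on its sulfonyl sulfur joined through a urea, and in this assay compound 1 gives 8100 nM. Compound 2 `CC(C)c1cccc(C(C)C)c1OC(=O)NS(=O)(=O)N1CCCC1` instead links the core through a carbamate to a sulfonyl bearing a pyrrolidin-1-yl group; in this assay compound 2 gives 53000 nM. Of the two numbers compound 2 has the higher one, so it is the weaker inhibitor, and its gap to compound 1 lies beyond the usual scatter.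

Compound 3 `CC(C)c1cccc(C(C)C)c1OC(=O)NS(=O)(=O)Nc1ccccc1` keeps the carbamate linkage of compound 2 and changes only the group on the sulfonyl sulfur: anilino in place of pyrrolidin-1-yl on a sulfonyl sulfur. No direct comparison of this kind has been measured. Because compound 1 gives 8100 nM while also carrying a hydrogen-bond donor on its sulfonyl sulfur, which compound 3 gains too, the expected change is a 3.3-fold lower number from compound 2 to compound 3 (0.52 log units; beyond the scatter). In this assay compound 3 is therefore estimated at 16000 nM, within a range from 4000 nM to 60000 nM.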

Compound 3, half-maximal inhibitory concentration: 38100 nM
Compound 3: the middle estimate sits 2.4-fold (0.38 log units) below what was measured; measured number inside the range.
By their numbers in this assay, from the lowest: compound 1; then compounds 3 and 2 (each within the scatter of the next).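

In this assay, replacing pyrrolidin-1-yl with anilino on a sulfonyl sulfur gives a 1.4-fold lower number from compound 2 to compound 3 (0.14 log units; within the scatter). Among these compounds, with the carbamate linkage held fixed, this place therefore accepts a six-membered aromatic ring of carbon only in place of a five-membered non-aromatic ring with little measurable effect on the number, and this single change gives the first direct reading at this position. The anilino group also brings a hydrogen-bond donor that pyrrolidin-1-yl lacks, yet in this one pair that gain comes with no step beyond the scatter, and no supporting measurement is available to explain the result.

Compound 1 differs from compound 2 and compound 3 both in its linkage to the shared core and in the group on the sulfonyl sulfur, so the compounds shown cannot separate the contributions of those two places to its value. Going by these compounds, it also remains open whether a hexylamino group on the carbamate series, or a benzylamino group or a carboxylic acid on the anilino ring, would move the number beyond the scatter.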